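Shifting the Fluorine on the Phenyl Ketone

A few compounds are considered here, and "the series" means these few. Any claim that something is new, unique, unknown or untested is made for them only; others in the source may bear on it.

Measured compounds:
compound 1 `O=C(/C=C/C1=Cc2ccccc2OC1)c1ccccc1F`: 64.4%
compound 2 `O=C(/C=C/C1=Cc2ccccc2OC1)c1cccc(F)c1`: 52.4%

Both compounds were examined in a functional assay on the whole organism for inhibition, with Mus musculus as the target, with a stated time of 1 h, at a dose of 30 mg/kg by the intraperitoneal route; a higher number here means more inhibition at the dose given (going by the name of the read-out), a lower number less inhibition. Compound 1 gives 64.4%, and compound 2 gives 52.4%, so compound 2 stands lowest of the two numbers, with compound 1 its nearest neighbour and the only other point. Going by the values given here, the one step that connects them, 3-fluorophenyl in place of 2-fluorophenyl on a carbonyl carbon, gave a number 12 percentage points lower from compound 1 to compound 2 (beyond the scatter).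

Compound 3 `O=C(/C=C/C1=Cc2ccccc2OC1)c1ccc(F)cc1` continues this series: 4-fluorophenyl in place of 3-fluorophenyl on a carbonyl carbon. The step from compound 1 to compound 2 is the only measured one that bears on a move of the fluorine on this phenyl, and it was modest though beyond the scatter. Whether a further move to the 4-position continues downward, reverses, or changes nothing is not shown by the two numbers; the single step gives no trend to extend. A change of about the scatter or less is therefore expected, a number 2.4 percentage points lower from compound 2 to compound 3 (within the scatter), leaning slightly lower. Compound 3 is estimated at 50% in this assay, with a range from 36% to 64%.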

Compound 3, a percentage reported as inhibition, in the whole organism at one dose (the size of the read-out at that dose, not a potency): 65.6%
Estimate against measurement, compound 3: 15.6 percentage points below; the measured number lies above the stated range.
By their numbers in this assay, from the lowest: compound 2; then compounds 1 and 3 (each within the scatter of the next).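

In this assay, moving the fluorine around the phenyl ketone does not produce a steady decline: the change to 4-fluorophenyl from 3-fluorophenyl gave a number 13.2 percentage points higher from compound 2 to compound 3 (beyond the scatter), a step that runs opposite to the earlier a number 12 percentage points lower from compound 1 to compound 2 (beyond the scatter). The direct comparison of the two outer members, 4-fluorophenyl in place of 2-fluorophenyl, gave a number 1.2 percentage points higher from compound 1 to compound 3 (within the scatter), so these two compounds cannot be told apart here, and compound 2, with its 3-fluorophenyl group, alone stands lowest, with its steps to both others beyond the scatter. Nothing available explains why the 3-fluorophenyl compound differs from the other two.

As far as these compounds go, what remains open is whether this pattern belongs to fluorine itself, or whether a chlorine or a methoxy group in the same three places on the phenyl ring would give the same low middle member. The compounds shown also leave open how a plain phenyl group without any substituent on the carbonyl carbon would compare, and whether the similarity of compound 1 and compound 3 would persist at another dose or time.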